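A few compounds are considered here, and "the series" means these few. Any claim that something is new, unique, unknown or untested is made for them only; others in the source may bear on it.

Measured compounds:
- compound 1 `COc1cc2c(Oc3ccc(NC(=O)c4cc(-c5ccccc5)ccn4)cc3F)ccnc2cc1OCCCN1CCCC1`: 210 nM
- compound 2 `COc1ccc(-c2ccnc(C(=O)Nc3ccc(Oc4ccnc5cc(OCCCN6CCCC6)c(OC)cc45)c(F)c3)c2)c(OC)c1`: 740 nM

In a functional assay on MKN-45 cells (Homo sapiens) for cytotoxicity, read by MTT assay, with a stated time of 72 h (a lower number here means a stronger inhibitor, a higher number a weaker inhibitor), compound 1 gives 210 nM, the lowest of the two numbers; compound 2 gives 740 nM. Among the compounds with values here, the one measured step, a 3.5-fold higher number from compound 1 to compound 2 (0.55 log units; beyond the scatter), concerns the aryl group on the aromatic carbon, not the ring that carries the carbonyl.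

Compound 3 `COc1cc2c(Oc3ccc(NC(=O)c4nccc(-c5ccccc5)n4)cc3F)ccnc2cc1OCCCN1CCCC1` is not yet measured. It differs from compound 1 as 4-phenylpyrimidin-2-yl in place of 4-phenylpyridin-2-yl on a carbonyl carbon. Within the data shown here, no measured step bears on this change: the pair of compound 1 and compound 2 alters a different place in the molecule, so it says nothing about swapping the pyridine for a pyrimidine. Expectation in this assay therefore rests on the shared core alone, and no step beyond the scatter is expected; the estimate for the step is a 1.4-fold higher number from compound 1 to compound 3 (0.15 log units; within the scatter). The value expected for compound 3 is 300 nM, within 90 nM to 1000 nM.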

Compound 3, half-maximal inhibitory concentration: 1360 nM
Compound 3: middle estimate off by 4.5-fold (0.66 log units), on the low side; the measured number lies above the stated range.
By their numbers in this assay, from the lowest: compound 1; then compounds 2 and 3 (each within the scatter of the next).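

The ring on the carbonyl carbon is not a silent position in this assay: 4-phenylpyrimidin-2-yl in place of 4-phenylpyridin-2-yl gives a 6.5-fold higher number from compound 1 to compound 3 (0.81 log units; beyond the scatter), so this site responds to the ring itself as well as to the aryl group it carries. Within the data shown here, the exchange keeps the heavy-atom count and trades only one ring carbon for a nitrogen, which adds one hydrogen-bond acceptor by count, and this single change is enough to move the number beyond the scatter. No measured evidence here indicates what underlies this step.

Still open, as far as these compounds go, is whether the step from pyridine to pyrimidine keeps its size when 2,4-dimethoxyphenyl replaces phenyl. The compounds shown also leave open how an amine or a carboxylic acid on the ring on the carbonyl carbon would read in this assay.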